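The source may hold more compounds than are shown below. What is called first, only, known or untested is meant among the compounds shown, and "the series" means these compounds.

Measured so far:
compound 1 `N#Cc1ccc(-c2ccc(OCC(CN3C(=O)c4ccccc4C3=O)N(O)C=O)cc2)cc1`: 0.3 h
compound 2 `N#Cc1ccc(-c2ccc(OCC(CN3C(=O)CCC3=O)N(O)C=O)cc2)cc1`: 0.6 h

In an in vivo ADME assay on the whole organism (Macaca fascicularis) for pharmacokinetics, at a dose of 3 mg/kg by the intravenous route (on this read-out higher numbers stand for a longer-lived compound and lower numbers for a shorter-lived compound), compound 1 gives 0.3 h, and compound 2 gives 0.6 h. Within the data shown here, these two numbers lie within the scatter of each other, so compound 1 stands level with the only other measured compound.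

Compound 3 `CC1(C)NC(=O)N(CC(COc2ccc(-c3ccc(C#N)cc3)cc2)N(O)C=O)C1=O` has not yet been measured. It keeps the core of compound 1 and carries this change: a group of 9 heavy atoms (5 carbon, 2 nitrogen, 2 oxygen; one five-membered non-aromatic ring with 2 hetero atoms) in place of a group of 11 heavy atoms (8 carbon, 1 nitrogen, 2 oxygen; one five-membered non-aromatic ring with 1 hetero atom, one six-membered aromatic ring of carbon only), on a saturated chain carbon, two bonds along the chain from an amide-type nitrogen. The entering group is 4,4-dimethyl-2,5-dioxoimidazolidin-1-yl.

Among the measured compounds shown here, only one measured step bears on this. The step of a 2.0-fold higher number from compound 1 to compound 2 (0.30 log units; within the scatter) removes the same group from the same place, and it lies within the scatter. For the measured compounds named here, no measured compound carries the entering group, so this single step is weak evidence. On that basis no change beyond the scatter is expected in this assay, and any direction is tentative.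

The expected step is a 1.7-fold higher number from compound 1 to compound 3 (0.22 log units; within the scatter). Compound 3 is estimated at 0.5 h, with an expected range of 0.25 h to 1 h.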

Compound 3, half-life: 7.7 h
For compound 3 the middle estimate is 15-fold (1.19 log units) below the measured one; measured number above the stated range.
By their numbers in this assay, from the lowest: compounds 1 and 2 (each within the scatter of the next); then compound 3.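

In this assay, the group on the saturated chain carbon, two bonds along the chain from an amide-type nitrogen, can move the read-out well beyond the scatter: 4,4-dimethyl-2,5-dioxoimidazolidin-1-yl gives a 26-fold higher number from compound 1 to compound 3 (1.41 log units; beyond the scatter), and in place of 2,5-dioxopyrrolidin-1-yl it gives a 13-fold higher number from compound 2 to compound 3 (1.11 log units; beyond the scatter). Losing the six-membered aromatic ring is not enough to produce a step of this size, as the only earlier step at this place, which also removes that ring, is a 2.0-fold higher number from compound 1 to compound 2 (0.30 log units; within the scatter). No measurement at hand gives a cause for the large steps to compound 3.

The compounds shown do not separate the contribution of the two methyl groups from that of the second ring nitrogen with its amide hydrogen, a question that 2,5-dioxoimidazolidin-1-yl without the methyl groups, or 3,3-dimethyl-2,5-dioxopyrrolidin-1-yl, would address. On these data alone, it also remains open whether larger groups at the same carbon of the entering ring, such as two ethyl groups, or a different group at this place, such as a morpholine, would keep a half-life in this range.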